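A few compounds are considered here, and "the series" means these few. Any claim that something is new, unique, unknown or untested is made for them only; others in the source may bear on it.

In a physicochemical assay for solubility, read by HPLC, with a stated time of 24 h (on this read-out lower numbers stand for lower solubility and higher numbers for higher solubility), compound 1 (`CC(C)(C)c1[nH]cnc1/C=c1\[nH]c(=O)/c(=C/c2cccc(C(=O)c3ccccc3)c2)[nH]c1=O`) gives < 0.1 ug/mL as its reading, and that is a limit, not a number. Compound 2 (`CC(C)(C)c1[nH]cnc1/C=c1\[nH]c(=O)/c(=C/c2cccc(C(=O)c3ccncc3)c2)[nH]c1=O`) gives < 0.1 ug/mL as its reading, again a limit. Compound 2 therefore has no number of its own. Within the data shown here, the one measured step is a step that the two limits leave unreadable from compound 1 to compound 2 and so offers no size to carry forward, although it falls at the same carbonyl carbon as the next change. Compound 3 (`CC(C)(C)c1[nH]cnc1/C=c1\[nH]c(=O)/c(=C/c2cccc(C(=O)c3cccs3)c2)[nH]c1=O`) carries thiophen-2-yl in place of pyridin-4-yl on a carbonyl carbon. Because of the limit of < 0.1 ug/mL in this assay, at which 2 of the 2 values shown sit, no step beyond the scatter can be expected in either direction. The estimated step is a step that the limit leaves unreadable from compound 2 to compound 3 in this assay with neither direction favoured. Compound 3 is expected at 0.05 ug/mL within an estimated range of 0.02 ug/mL to 0.15 ug/mL and will quite likely be reported only as a limit.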

Compound 3, solubility: < 0.1 ug/mL
Compound 3 was reported as a limit; the forecaster's own chance of this, stated with the estimate: 85%; the middle value is on the limit's open side.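

No step to compound 3 can be read from compound 1 or compound 2, because all three readings are held at one limit: the limit of < 0.1 ug/mL in this assay, at which 3 of the 3 values shown sit.

The compounds shown leave open whether phenyl, pyridin-4-yl and thiophen-2-yl on the carbonyl carbon differ at all in this assay.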